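Benzyl substituent change in a dopamine receptor series

The source may hold more compounds than are shown below. What is called first, only, known or untested is meant among the compounds shown, and "the series" means these compounds.

Measured compounds:
compound 1 `COc1ccc(N(Cc2cccc(F)c2)NC(=O)NCCCN2CCN(c3ccccc3OC)CC2)cc1`: 6.2 nM
compound 2 `COc1ccc(N(Cc2cccc(OC)c2)NC(=O)NCCCN2CCN(c3ccccc3OC)CC2)cc1`: 33 nM

Within the data shown here, in an assay on CHO cells for displacement of a labelled ligand from D(4) dopamine receptor (Homo sapiens), read by radioligand binding (a lower number here means a stronger inhibitor, a higher number a weaker inhibitor), compound 2 holds the higher of the two numbers so far; its only neighbour is compound 1, and the step of a 5.3-fold higher number from compound 1 to compound 2 (0.73 log units; beyond the scatter) separates them, well outside the usual scatter. Compound 3 `COc1ccc(N(Cc2ccc(C#N)cc2)NC(=O)NCCCN2CCN(c3ccccc3OC)CC2)cc1` remains to be measured. It differs from compound 2 by 4-cyanophenyl in place of 3-methoxyphenyl on a saturated chain carbon bound to a nitrogen on an aromatic ring.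

Among the measured compounds shown here, the one measured step bears on the same place: replacing fluoro with methoxy on that aromatic ring gave a 5.3-fold higher number from compound 1 to compound 2 (0.73 log units; beyond the scatter) and made compound 2 the weaker of the pair. The present change removes that methoxy ring altogether and brings in a nitrile-bearing ring with the same count of heavy atoms and acceptors. For the measured compounds named here, no measured pair covers a nitrile here, so the direction rests on the single fact that the methoxy compound is the weakest of the two and a change at this position shifted the number by a modest amount.

Compound 3 is therefore expected to fall somewhat below compound 2, estimated at 15 nM with a range of 4 nM to 60 nM. The expected step is a 2.2-fold lower number from compound 2 to compound 3 (0.34 log units; beyond the scatter).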

Compound 3, inhibition constant: 16 nM
The estimate for compound 3 lay 1.1-fold (0.03 log units) below the measured number, within the range that was stated.
By their numbers in this assay, from the lowest: compound 1; then compound 3; then compound 2.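

In this assay, the 4-cyanophenyl group gives a 2.1-fold lower number from compound 2 to compound 3 (0.31 log units; beyond the scatter) and so recovers part of what the 3-methoxyphenyl group lost, which shows that the number at this position can move down as well as up. Against the 3-fluorophenyl group, the same 4-cyanophenyl group gives a 2.6-fold higher number from compound 1 to compound 3 (0.41 log units; beyond the scatter) and leaves compound 3 in the middle of the series, so the three rings on this saturated chain carbon give three numbers that are separated beyond the scatter, with compound 1 still the lowest. Nothing at hand accounts for this order or for the size of either step.

On these data alone, the change replaces the methoxy group with a nitrile and also moves the substituent from the ring place named 3 to the one named 4, so the share of each in the step stays open. As far as these compounds go, how an unsubstituted phenyl ring, or a ring bearing a carboxylic acid or an aminomethyl group, would stand against these three also remains open.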